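B-cell series: swapping the side chain on compound 1

This account rests on a few compounds, and the source may have more. Where it says the series, first, only, none or still open, it means among the compounds named here.

Compound 1 `Nc1nc(O)c2c(n1)n(C1OC(CO)[C@@H](O)[C@H]1O)c(=O)n2CC(O)CSc1ccccc1` gives 142 uM in a functional assay (B cells) with Mus musculus as the target; on this read-out higher numbers stand for an effect only at larger amounts of compound and lower numbers for an effect already at smaller amounts. Among the three numbers in hand this is the highest: compound 2 `C=CCn1c(=S)n(C2OC(COCc3ccccc3)[C@H]3OC(C)(C)O[C@@H]23)c2nc(N)nc(O)c21` gives 47 uM in this assay and compound 3 `C=CCn1c(=O)n(C2C[C@H](O)C(CO)O2)c2nc(N)nc(O)c21` gives 30 uM, both lower than compound 1 by more than the usual scatter. For the measured compounds named here, no pair of measured compounds differs in only one place, so no single-point step is available. Compound 4 `N#Cc1ccc(Cn2c(=O)n(C3OC(CO)[C@@H](O)[C@H]3O)c3nc(N)nc(O)c32)cc1` differs from compound 1 in one place: 4-cyanophenyl in place of 1-hydroxy-2-(phenylsulfanyl)ethyl on a saturated chain carbon bound to an aromatic nitrogen. Given that every other side chain seen here sits below compound 1, a moderate downward step in this assay is expected, though with wide uncertainty. Compound 4 is expected to give about 60 uM, between 15 uM and 250 uM. This corresponds to an expected step of a 2.4-fold lower number from compound 1 to compound 4 (0.37 log units; beyond the scatter).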

Compound 4, concentration for half-maximal effect: 15 uM
Compound 4: the middle estimate sits 4.0-fold (0.60 log units) above what was measured, within the range that was stated.
By their numbers in this assay, from the lowest: compounds 4, 3 and 2 (each within the scatter of the next, the first and the last beyond it); then compound 1.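

For the compounds shown here, at the saturated chain carbon bound to an aromatic nitrogen, 4-cyanophenyl in place of 1-hydroxy-2-(phenylsulfanyl)ethyl gives a 9.5-fold lower number from compound 1 to compound 4 (0.98 log units; beyond the scatter) in this assay, the first single-place step. The hydroxyl and the sulfur of the leaving group are therefore not required for activity at this level. Nothing on hand explains the size of this step.

Open, as far as these compounds go, is whether the gain belongs to the nitrile or to the ring alone. A plain phenyl, or an amine or carboxylic acid in place of the nitrile, would separate the two.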